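The source may report more compounds than this note shows. Statements on the series, on what has been measured and on what is new or still open speak of the compounds shown alone.

Compound 1 has the structure `O=C(Nc1ccccc1)c1cc(Br)ccc1O`. In an assay on isolated protein for inhibition of thiosulfate sulfurtransferase (Homo sapiens), with a stated time of 60 min, in the absence of a further agent (a higher number here means a weaker inhibitor, a lower number a stronger inhibitor), compound 1 gives only a limit of the assay, > 100000 nM. Compound 2, `O=C(Nc1ccccc1)c1cc(Br)cc(Br)c1O`, carries bromo in place of hydrogen on an aromatic carbon. In this assay compound 2 also gives only a limit, > 100000 nM. The step between them, a step that the two limits leave unreadable from compound 1 to compound 2, cannot be read because of the limit of > 100000 nM in this assay, at which 3 of the 3 values shown sit. Compound 3, `COc1ccccc1C(=O)Nc1ccc(Sc2nc3ccccc3s2)c(Cl)c1`, rests on another core; the difference between the two cores is not broken down here. In this assay compound 3 gives only a limit, > 100000 nM. Compound 4, `COc1c(Br)cccc1C(=O)Nc1ccc(Sc2nc3ccccc3s2)c(Cl)c1`, is still unmeasured and differs from compound 3 by bromo in place of hydrogen on an aromatic carbon. This is the same kind of change as from compound 1 to compound 2, though not the same: there the bromo entered ortho to a hydroxy group, meta to a bromo group and meta to a group of 9 heavy atoms, whereas here it enters ortho to a methoxy group and meta to a large group. With the earlier step unreadable and every measured value sitting at the limit, the expectation is a step that the limit leaves unreadable from compound 3 to compound 4. In this assay compound 4 is expected to give about 150000 nM, plausibly between 40000 nM and 600000 nM, most likely reported again only as a limit.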

Compound 4, half-maximal inhibitory concentration: > 100000 nM
Compound 4 ended at the assay's limit (the forecaster's own chance of this, stated with the estimate: 85%); the middle value lies beyond the limit too.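

The bromo step between compound 3 and compound 4 has no readable size, because both compounds give only a limit and not a number: the limit of > 100000 nM in this assay, at which 4 of the 4 values shown sit.

The compounds shown leave open whether bromo in place of hydrogen changes inhibition at all in this assay, and which change to these structures would give a measurable value.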